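Moving the chlorine on the chlorophenyl arm of compound 3

The source may report more compounds than this note shows. Statements on the series, on what has been measured and on what is new or still open speak of the compounds shown alone.

Measured compounds:
- compound 1, `Oc1cccc(-c2cc(-c3ccncc3)nc(-c3ccccc3Cl)c2)c1`: 0%
- compound 2, `Oc1cccc(-c2cc(-c3ccco3)nc(-c3ccccc3Cl)c2)c1`: 0%
- compound 3, `Oc1cccc(-c2cc(-c3ccc(Cl)cc3)nc(-c3ccsc3)c2)c1`: 11.7%

All three were tested in an assay on isolated protein for inhibition of DNA topoisomerase 1 (Homo sapiens), with a stated time of 30 min, tested at 100 uM; on this read-out lower numbers stand for a weaker effect and higher numbers for a stronger effect at the one concentration tested. Compound 3 stands highest of the three, and its gap to compound 1 and to compound 2 is beyond the usual scatter, so it is the strongest of the measured set. Compound 1 and compound 2 sit together at the bottom; the step of no change at the digits printed from compound 1 to compound 2 (within the scatter) shows no change.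

Compound 4, `Oc1cccc(-c2cc(-c3ccsc3)nc(-c3ccccc3Cl)c2)c1`, has not yet been measured. It differs from compound 3 by 2-chlorophenyl in place of 4-chlorophenyl on an aromatic carbon.

Within the data shown here, no measured step changes a chlorophenyl group in this way, so the only step on record does not bear on it directly. What the data do show is that compound 1 and compound 2, the two compounds that carry a 2-chlorophenyl group, both give no inhibition in this assay, while compound 3, with a 4-chlorophenyl group, is the only one with a measurable effect. On that basis a downward step is expected, a number 7.7 percentage points lower from compound 3 to compound 4 (within the scatter), and compound 4 is estimated to give 4%, within a range from 0% to 15%.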

Compound 4, a percentage reported as inhibition, at one concentration (the size of the read-out at that concentration, not a potency): 0%
Estimate against measurement, compound 4: 4 percentage points above, and the stated range covers the measured number.
By their numbers in this assay, from the lowest: compounds 1, 2 and 4 (each within the scatter of the next); then compound 3.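

Among these compounds, the pair of compound 3 and compound 4 is the first direct test of where the chlorine sits: in this assay, the two have the same atoms, and changing 4-chlorophenyl to 2-chlorophenyl gives a number 11.7 percentage points lower from compound 3 to compound 4 (beyond the scatter). With 2-chlorophenyl in place, changing the group on the other arm makes no visible difference, with no change at the digits printed from compound 2 to compound 4 (within the scatter) and no change at the digits printed from compound 1 to compound 4 (within the scatter), so thiophen-3-yl does not by itself bring the effect seen with compound 3. Nothing measured here explains why the position of the chlorine matters.

The compounds shown leave open whether the 4-chlorophenyl group would also lift the read-out when paired with furan-2-yl or pyridin-4-yl, since only the thiophen-3-yl pair allows a direct comparison of the two chlorophenyl groups. They also leave open whether chlorine is needed at all, which a plain phenyl group, or a methoxy group or an amine in place of the chlorine, would begin to answer, while the single tested concentration gives the size of an effect and not a potency.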